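The source may hold more compounds than are shown below. What is called first, only, known or untested is meant among the compounds shown, and "the series" means these compounds.

Measured compounds in a functional assay on HCT-116 cells (Homo sapiens) for inhibition, read by MTT assay, with a stated time of 48 h; a higher number here means a weaker inhibitor, a lower number a stronger inhibitor:

Compound 1 `Clc1cccc(CSc2nnc(-c3ccncc3)n2-c2ccccc2)c1`, compound 1 gives 9820 nM.
Compound 2 `Brc1cccc(CSc2nnc(-c3ccncc3)n2-c2ccccc2)c1`, compound 2 gives 8170 nM.
Compound 3 `COc1ccc(/C=N/NC(=O)CSc2nnc(-c3ccncc3)n2-c2ccccc2)cc1`, compound 3 gives 19200 nM.

All three share the same core, a five-membered ring carrying a pyridyl group, a phenyl group and a sulfur link. Compound 3 gives the highest of the three numbers; against compound 1 the gap is within the usual scatter of repeated measurements, against compound 2 it is just beyond it. Going by the values given here, the only step measured between two compounds that differ in one place is a 1.2-fold lower number from compound 1 to compound 2 (0.08 log units; within the scatter).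

Compound 4 `O=C(CSc1nnc(-c2ccncc2)n1-c1ccccc1)N/N=C/c1cccc(F)c1` is not yet measured. It differs from compound 3 in one place: 3-fluorophenyl in place of 4-methoxyphenyl on a carbon with a double bond to nitrogen. Among the compounds with values here, the measured step between compound 1 and compound 2 concerns a halogen swap on a benzyl group and does not touch the hydrazone part where compound 3 and compound 4 differ, so no measured step bears directly on this change. Without a comparable step, the expectation is that the number for compound 4 stays close to that of compound 3, with no step beyond the scatter in either direction. The estimated step is a 1.3-fold lower number from compound 3 to compound 4 (0.11 log units; within the scatter). Compound 4 is therefore expected to give 15000 nM in this assay, within a range from 6000 nM to 40000 nM.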

Compound 4, half-maximal inhibitory concentration: > 50000 nM
Compound 4: no number, only a limit; the forecaster's own chance of this, stated with the estimate: 10%; at least 3.3-fold (0.52 log units) between middle value and limit.
By their numbers in this assay, from the lowest: compounds 2, 1 and 3 (each within the scatter of the next, the first and the last beyond it). At a limit, above all of these: compound 4.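

In this assay compound 4 gives only a limit of the assay and not a number: the limit of > 50000 nM in this assay, at which 1 of the 4 values shown sits. Going by these compounds alone, putting 3-fluorophenyl in place of 4-methoxyphenyl on a carbon with a double bond to nitrogen gives an at least 2.6-fold higher number from compound 3 to compound 4 (0.41 log units; beyond the scatter) and this is the first step here to go beyond the scatter. Within the data shown here, the only earlier step was the halogen swap on the benzyl group, with a 1.2-fold lower number from compound 1 to compound 2 (0.08 log units; within the scatter) and so the earlier compounds gave no sign that a single change could shift the number this clearly, while this result shows that the aromatic group at the hydrazone end can do so.

This one change alters both the substituent and its place on the ring, so the step cannot say which of the two matters, and a 4-fluorophenyl or a 3-methoxyphenyl group here would separate them. Also open, as far as these compounds go, is how a group of another kind on this ring, such as an amine or a carboxylic acid, would read in this assay, and how far above the limit compound 4 really lies.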